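The source may report more compounds than this note shows. Statements on the series, on what has been measured and on what is new or still open speak of the compounds shown alone.

In an ADME assay on Caco-2 cells (Homo sapiens) for permeability, read by LC-MS, in the apical to basolateral direction, with a stated time of 60 min, at pH 6.5 (on this read-out higher numbers stand for higher permeability and lower numbers for lower permeability), compound 1 (`Cc1cccc([C@@H](O)C(=O)N2N=CC[C@H]2C(=O)NCc2cc(Cl)ccc2-n2cnnn2)c1`) gives 9.7 10^-6 cm/s, compound 2 (`O=C(NCc1cc(Cl)ccc1-n1cnnn1)[C@@H]1CC=NN1C(=O)[C@H](O)c1ccccc1`) gives 7 10^-6 cm/s and compound 3 (`CCCC(=O)O[C@@H](C(=O)N1N=CC[C@H]1C(=O)NCc1cc(Cl)ccc1-n1cnnn1)c1ccc(F)cc1`) gives 25 10^-6 cm/s, the highest of the three numbers and beyond the scatter of both others. Compound 4 (`O=C(O[C@@H](C(=O)N1N=CC[C@H]1C(=O)NCc1cc(Cl)ccc1-n1cnnn1)c1ccc(F)cc1)c1ccccc1`) differs from compound 3 by a single change: phenyl in place of propyl on a carbonyl carbon, in words phenyl in place of propyl on a carbonyl carbon. Within the data shown here, the set holds only one measured step, a 1.4-fold lower number from compound 1 to compound 2 (0.14 log units; within the scatter), which is hydrogen in place of methyl on an aromatic carbon. Among the measured compounds shown here, that step lies elsewhere in the molecule and within the scatter, so it bears only weakly on the new change, and no measured pair exchanges propyl for phenyl. With so little evidence, no shift beyond the scatter is expected in this assay. The expected step, a 1.1-fold lower number from compound 3 to compound 4 (0.06 log units; within the scatter), stays within the scatter. For compound 4 the estimated value is 22 10^-6 cm/s, with an expected range from 9 10^-6 cm/s to 50 10^-6 cm/s.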

Compound 4, apparent permeability: 43 10^-6 cm/s
Compound 4: the middle estimate sits 2.0-fold (0.29 log units) below what was measured; the range from low to high includes it.
By their numbers in this assay, from the lowest: compounds 2 and 1 (each within the scatter of the next); then compounds 3 and 4 (each within the scatter of the next).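

In this assay, the exchange of propyl for phenyl on a carbonyl carbon gives a 1.7-fold higher number from compound 3 to compound 4 (0.24 log units; within the scatter), so the two compounds cannot be told apart on this read-out. Among these compounds, this is the first measured change at this position, and it shows that a six-membered aromatic ring of carbon only, with 6 heavy atoms in place of 3, can stand there without a step beyond the scatter. Nothing available explains this result.

The compounds shown leave open how a longer chain, a methoxy-substituted phenyl or an amine at this carbonyl carbon would read in this assay. With a single pair for this exchange, they also leave open whether phenyl in place of propyl would give a similar step elsewhere in the series.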